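Metabolic Stability of Two Analogues and One Untested Compound

This account rests on a few compounds, and the source may have more. Where it says the series, first, only, none or still open, it means among the compounds named here.

Measured compounds:
compound 1 `Cc1nc(N2CCN(C)CC2)c2nc(-c3ccccc3Cl)n(C3CC3)c2n1`, 98%
compound 2 `Cc1nc(N2CCN(C)CC2)c2nc(-c3cccc(Cl)c3)n(C3CCOCC3)c2n1`, 45%

In an ADME assay (liver) for metabolic stability, with Liver microsome (Canis lupus familiaris) as the target, read by LC-MS, using microsomes, with a stated time of 30 min, tested at 4 uM (a higher number here means that more of the compound is left, a lower number that less of the compound is left), compound 1 gives 98%. In this assay compound 2 gives 45%, the lower of the two numbers recorded, and its gap to compound 1 is beyond the scatter of the measurement. Among the compounds with values here, the two compounds differ in more than one place, so no single structural step between them is set out.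

Compound 3 `Cc1nc(N2CCN(C)CC2)c2nc(-c3ccccc3C3CC3)n(C3CCOCC3)c2n1` has not yet been measured in this assay. It differs from compound 2 in one place: 2-cyclopropylphenyl in place of 3-chlorophenyl on an aromatic carbon. The oxan-4-yl group of compound 2 is retained.

Within the data shown here, nothing among the measured compounds isolates the effect of this particular change, so the step from compound 2 to compound 3 is expected to be modest and its direction is open; the estimate a number 5 percentage points higher from compound 2 to compound 3 (within the scatter) is taken as close to no change beyond the scatter. Compound 3 is therefore expected to give about 50% in this assay, within a range from 25% to 80%.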

Compound 3, percent of the compound remaining: 69%
Compound 3: middle estimate off by 19 percentage points, on the low side, and the stated range covers the measured number.
By their numbers in this assay, from the lowest: compound 2; then compound 3; then compound 1.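

Within the data shown here, with the oxan-4-yl group held in place, the pair of compound 2 and compound 3 isolates a change on the aromatic carbon between two ring nitrogen atoms, something the earlier compounds could not do because they differ in more than one place. In this assay, putting 2-cyclopropylphenyl in place of 3-chlorophenyl gives a number 24 percentage points higher from compound 2 to compound 3 (beyond the scatter) and so shows that the read-out responds to the group at this position, with more compound left for the entering group of 9 heavy atoms than for the leaving group of 7. Nothing in the information available accounts for this step, so it stands as an observation only.

The compounds shown leave open whether the step belongs to the cyclopropyl group itself or to where the substituent sits on the phenyl ring, a question that 3-cyclopropylphenyl or 2-chlorophenyl on the same oxan-4-yl compound would separate. Also open, on these data alone, is how a plain phenyl, or a phenyl carrying a methoxy group or an amine, would read at this position, and whether the step would carry over to compounds with a different group in place of oxan-4-yl.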